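Swapping the aryl amine on a shared quinazoline-free core toward a dimethoxy group

The source may hold more compounds than are shown below. What is called first, only, known or untested is meant among the compounds shown, and "the series" means these compounds.

Of the compounds shown here, three sharing one core have been tested in a functional assay on MDA-MB-231 cells (Homo sapiens) for cytotoxicity, read by MTT assay, with a stated time of 72 h; a higher number here means a weaker inhibitor, a lower number a stronger inhibitor. Compound 1 `COc1ccccc1Nc1nc(SCc2ccc(C(F)(F)F)cc2)nc2ccccc12` carries a 2-methoxyphenyl on the nitrogen, and in this assay compound 1 reaches only the limit > 50000 nM, a value at which the assay stops counting. Compound 2 `O=[N+]([O-])c1cccc(Nc2nc(SCc3ccc(C(F)(F)F)cc3)nc3ccccc23)c1` carries a 3-nitrophenyl there and in this assay compound 2 gives 31500 nM. Compound 3 `FC(F)(F)c1ccc(CSc2nc(Nc3ccc(Cl)cc3)c3ccccc3n2)cc1` carries a 4-chlorophenyl and in this assay compound 3 gives 15100 nM, the lowest number among the two numbers that are known, with the nearest being a 2.1-fold lower number from compound 2 to compound 3 (0.32 log units; beyond the scatter). The other steps are an at least 1.5-fold lower number from compound 1 to compound 2 (0.20 log units; that floor lies within the scatter) and an at least 3.3-fold lower number from compound 1 to compound 3 (0.51 log units; beyond the scatter), the latter resting on (the limit of > 50000 nM in this assay, at which 1 of the 3 values shown sits).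

Compound 4 `COc1ccc(Nc2nc(SCc3ccc(C(F)(F)F)cc3)nc3ccccc23)cc1OC` differs from compound 3 by 3,4-dimethoxyphenyl in place of 4-chlorophenyl on a nitrogen on an aromatic ring. Going by the values given here, no measured step covers exactly this exchange, but the only methoxy-bearing compound, compound 1, reached only the assay limit, and every measured step away from the chlorophenyl raised the number. The expectation is therefore a higher number, a 2.3-fold higher number from compound 3 to compound 4 (0.37 log units; beyond the scatter). For compound 4 the estimate in this assay is 35000 nM, with a likely range from 12000 nM to 100000 nM, and a fair chance that only a limit is reported.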

Compound 4, half-maximal inhibitory concentration: 18900 nM
Beside the measured number, compound 4's estimate is 1.9-fold (0.27 log units) above it; the measured number falls inside the stated range.
By their numbers in this assay, from the lowest: compounds 3, 4 and 2 (each within the scatter of the next, the first and the last beyond it). At a limit, above all of these: compound 1.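

In this assay, the exchange on the nitrogen gives a 1.3-fold higher number from compound 3 to compound 4 (0.10 log units; within the scatter), so the 3,4-dimethoxyphenyl cannot be told apart from the 4-chlorophenyl here, and methoxy groups on this ring do not in themselves go with the assay limit seen for compound 1. The comparison with the 3-nitrophenyl gives a 1.7-fold lower number from compound 2 to compound 4 (0.22 log units; within the scatter), which places compound 4 within the scatter of both compound 2 and compound 3, even though those two compounds lie beyond the scatter of each other. On these data alone, the comparison with the 2-methoxyphenyl gives an at least 2.6-fold lower number from compound 1 to compound 4 (0.42 log units; beyond the scatter), a gap whose true size remains unknown: the limit of > 50000 nM in this assay, at which 1 of the 4 values shown sits.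

The compounds shown leave open whether a single methoxy group would behave like the pair, as a 4-methoxyphenyl on the same nitrogen would test, and whether a ring bearing an amine or a carboxylic acid would stay in the same range. They also leave open how far these comparisons hold once the rest of the shared core changes, as every compound here keeps the same trifluoromethyl-bearing side.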